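Methoxy in place of trifluoromethyl: compound 4 expected

This account rests on a few compounds, and the source may have more. Where it says the series, first, only, none or still open, it means among the compounds named here.

The three measured compounds share one core and differ only at the saturated chain carbon bound to the amide-type nitrogen in the ring. In a functional assay on Jurkat cells (Homo sapiens) for antiproliferative activity, read by MTT assay, with a stated time of 48 h (a higher number here means a weaker inhibitor, a lower number a stronger inhibitor), compound 1 `CCN1C(=O)C(=O)c2cc(/C=C/C(=O)OC)ccc21` gives 200 nM. Compound 2 `COC(=O)/C=C/c1ccc2c(c1)C(=O)C(=O)N2Cc1ccccc1` gives 70 nM; the step is a 2.9-fold lower number from compound 1 to compound 2 (0.46 log units; beyond the scatter). Compound 3 `COC(=O)/C=C/c1ccc2c(c1)C(=O)C(=O)N2Cc1ccc(C(F)(F)F)cc1` gives 360 nM. The step is a 5.1-fold higher number from compound 2 to compound 3 (0.71 log units; beyond the scatter). Among the three numbers, that of compound 3 is the highest; compound 1 sits within the scatter of it, and compound 2 lies beyond.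

Compound 4 `COC(=O)/C=C/c1ccc2c(c1)C(=O)C(=O)N2Cc1ccc(OC)cc1` differs from compound 3 by methoxy in place of trifluoromethyl on an aromatic carbon. For the measured compounds named here, no measured compound carries a methoxy, so the only step bearing on this place is a 5.1-fold higher number from compound 2 to compound 3 (0.71 log units; beyond the scatter), which shows that the group on that aromatic carbon moves the number beyond the scatter. Whether methoxy there acts like hydrogen or like trifluoromethyl is not shown. The expected step is therefore a 2.4-fold lower number from compound 3 to compound 4 (0.38 log units; beyond the scatter), a modest lowering with wide uncertainty. Compound 4 is estimated at 150 nM, in the range 50 nM to 500 nM.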

Compound 4, half-maximal inhibitory concentration: 30 nM
For compound 4 the middle estimate is 5.0-fold (0.70 log units) above the measured one; measured number below the stated range.
By their numbers in this assay, from the lowest: compound 4; then compound 2; then compounds 1 and 3 (each within the scatter of the next).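

In this assay, the group on this aromatic carbon can move the number in either direction from hydrogen: methoxy lowers it (a 2.3-fold lower number from compound 2 to compound 4 (0.37 log units; beyond the scatter)), whereas trifluoromethyl raises it (a 5.1-fold higher number from compound 2 to compound 3 (0.71 log units; beyond the scatter)). Exchanging these two groups gives the largest step in the series (a 12-fold lower number from compound 3 to compound 4 (1.08 log units; beyond the scatter)), and 4-methoxyphenyl in place of methyl on the chain carbon also lowers the number beyond the scatter (a 6.7-fold lower number from compound 1 to compound 4 (0.82 log units; beyond the scatter)). Nothing given here accounts for these differences.

The compounds shown leave open whether a hydroxyl, an amine or a chlorine on this carbon would follow methoxy or trifluoromethyl, and whether methoxy would give the same step on another carbon of that ring. Also open, on these data alone, is how a carboxylic acid in place of the methyl ester would behave alongside the 4-methoxyphenyl group.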